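A few compounds are considered here, and "the series" means these few. Any claim that something is new, unique, unknown or untested is made for them only; others in the source may bear on it.

In an ADME assay on the whole organism (Rattus norvegicus, strain Wister-Han) for pharmacokinetics, read by LC-MS, at a dose of 3 mg/kg by the oral route (a higher number here means more compound in the circulation at the dose given, a lower number less compound in the circulation), compound 1 `CC1(C)c2cc(Cl)ccc2C(=O)N1c1cncc(OC2CN(C(=O)c3ncccc3Cl)C2)c1` gives 10800 ng.h/mL. Compound 2 `Cn1cc(C(=O)N2CC3(C2)CN(c2cncc(N4C(=O)c5ccc(Cl)cc5C4(C)C)c2)C3)cn1` gives 5660 ng.h/mL, within the usual scatter of compound 1. Compound 3 `CC1(C)c2cc(Cl)ccc2C(=O)N1c1cncc(N2CCN(S(C)(=O)=O)CC2)c1` gives 1640 ng.h/mL, a number beyond the scatter and lower than that of compound 1. For the measured compounds named here, no measured pair differs in one place only, so no direct precedent exists for the change under review.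

Compound 4 `Cn1cc(C(=O)N2CC(Oc3cncc(N4C(=O)c5ccc(Cl)cc5C4(C)C)c3)C2)cn1` keeps the rest of compound 1 and carries 1-methyl-1H-pyrazol-4-yl in place of 3-chloropyridin-2-yl on a carbonyl carbon. Going by the values given here, the same 1-methyl-1H-pyrazol-4-yl carbonyl occurs in compound 2 with 5660 ng.h/mL, the only measured guide to this group. A small downward step is therefore expected, with no step beyond the scatter as the likeliest reading. The estimated step is a 2.0-fold lower number from compound 1 to compound 4 (0.29 log units; within the scatter). For compound 4 the expected value is 5500 ng.h/mL, with an estimated range from 2000 ng.h/mL to 13000 ng.h/mL.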

Compound 4, area under the concentration-time curve: 7880 ng.h/mL
Compound 4: middle estimate off by 1.4-fold (0.16 log units), on the low side; the range from low to high includes it.
By their numbers in this assay, from the lowest: compound 3; then compounds 2, 4 and 1 (each within the scatter of the next).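

For the compounds shown here, the first one-place comparison in this assay is a 1.4-fold lower number from compound 1 to compound 4 (0.14 log units; within the scatter), so 1-methyl-1H-pyrazol-4-yl in place of 3-chloropyridin-2-yl on a carbonyl carbon gives no step that can be told from scatter. At this position, a five-membered aromatic ring with 2 hetero atoms and no chlorine therefore reads the same as a six-membered aromatic ring with 1 hetero atom and a chlorine, within the scatter of this one pair. No supporting measurement bears on why the two groups read alike.

Still open, on these data alone, is how this carbonyl carbon responds to a group of another kind, such as an amine or a carboxylic acid, in place of either aromatic ring. Also open, as far as these compounds go, is whether 3-chloropyridin-2-yl in place of 1-methyl-1H-pyrazol-4-yl on the carbonyl carbon of compound 2 would likewise stay within the scatter.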